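This account rests on a few compounds, and the source may have more. Where it says the series, first, only, none or still open, it means among the compounds named here.

The compounds measured so far:
compound 1, `C[Se]/C(=N\C(=O)c1cc2ccccc2s1)NC(=O)c1cc2ccccc2s1`; in a functional assay on HT-29 cells (Homo sapiens) for cytotoxicity, read by MTT assay, with a stated time of 72 h (a lower number here means a stronger inhibitor of growth, a higher number a weaker inhibitor of growth), compound 1 gives > 100000 nM, which is a limit of the assay rather than a number.
compound 2, `CS/C(=N\C(=O)c1sccc1Cl)NC(=O)c1sccc1Cl`; in this assay compound 2 gives > 100000 nM, again a limit.
compound 3, `CS/C(=N\C(=O)c1cnc2ccccc2c1)NC(=O)c1cnc2ccccc2c1`; in this assay compound 3 gives > 100000 nM, again a limit.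

For the measured compounds named here, compound 2 therefore stands where every value so far stands, at the limit noted in the limit of > 100000 nM in this assay, at which 3 of the 3 values shown sit; no number separates it from the others. Compound 4, `C[Se]/C(=N\C(=O)c1sccc1Cl)NC(=O)c1sccc1Cl`, differs from compound 2 in one place: a group of 2 heavy atoms (1 carbon, 1 selenium; no ring) in place of a group of 2 heavy atoms (1 carbon, 1 sulfur; no ring), on a carbon with a double bond to nitrogen. Going by the values given here, no step between two measured compounds is available to gauge this change. What is available is compound 1, which carries the same selenium-bearing group on a different core and also gives > 100000 nM, a limit. The expected step of a number no higher from compound 2 to compound 4 (the limit leaves the size open) is therefore estimated as none beyond the scatter. Compound 4 is expected to give about 100000 nM, most likely again reported as a limit, with a range from 30000 nM to 300000 nM.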

Compound 4, concentration for total growth inhibition: > 100000 nM
Compound 4 gave a limit, no number; the forecaster's own chance of this, stated with the estimate: 85%; the middle value lies on the limit itself.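

No step can be read from compound 2 to compound 4, because each gives only a limit rather than a number: the limit of > 100000 nM in this assay, at which 4 of the 4 values shown sit.

The compounds shown leave open whether the group with selenium in place of methylsulfanyl changes growth inhibition in this assay at all.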